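Replacing the 4-methoxyphenyl group of compound 3

The source may hold more compounds than are shown below. What is called first, only, known or untested is meant among the compounds shown, and "the series" means these compounds.

Among the compounds with values here, in a functional assay on A549 cells (Homo sapiens) for antiproliferative activity, read by MTT assay, with a stated time of 72 h (a lower number here means a stronger inhibitor, a higher number a weaker inhibitor), compound 1 (`O=C(N/N=C/c1ccccc1)Nc1ccc(Oc2ccnc3[nH]ccc23)cc1`) gives 17200 nM as the highest number so far. Compound 2 (`O=C(N/N=C/c1ccc(F)cc1)Nc1ccc(Oc2ccnc3[nH]ccc23)cc1`) gives the lowest (1430 nM). Compound 3 (`COc1ccc(/C=N/NC(=O)Nc2ccc(Oc3ccnc4[nH]ccc34)cc2)cc1`) stands second highest of the three (4300 nM).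

Compound 4 (`O=C(N/N=C/c1ccc(O)cc1Br)Nc1ccc(Oc2ccnc3[nH]ccc23)cc1`) carries 2-bromo-4-hydroxyphenyl in place of 4-methoxyphenyl on a carbon with a double bond to nitrogen.

Within the data shown here, three measured steps bear on this change. Fluoro in place of hydrogen gave a large drop (a 12-fold lower number from compound 1 to compound 2 (1.08 log units; beyond the scatter)). Methoxy in place of hydrogen gave a modest drop (a 4.0-fold lower number from compound 1 to compound 3 (0.60 log units; beyond the scatter)). Methoxy in place of fluoro gave a modest rise (a 3.0-fold higher number from compound 2 to compound 3 (0.48 log units; beyond the scatter)). Among the measured compounds shown here, no measured compound carries bromo or hydroxy, and none has two groups on this ring, so these steps guide the expectation only loosely.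

Compound 4 has a halogen on the ring, as does compound 2 (1430 nM), but it lacks the methoxy of compound 3 (4300 nM). A value near or slightly under that of compound 3 is therefore expected. In this assay the expected step is small (a 1.4-fold lower number from compound 3 to compound 4 (0.16 log units; within the scatter)) and not clearly beyond the scatter. In this assay the estimated value for compound 4 is 3000 nM (expected range 900 nM to 10000 nM).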

Compound 4, half-maximal inhibitory concentration: 5080 nM
Compound 4: the middle estimate sits 1.7-fold (0.23 log units) below what was measured, and the stated range covers the measured number.
By their numbers in this assay, from the lowest: compound 2; then compounds 3 and 4 (each within the scatter of the next); then compound 1.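

In this assay, 2-bromo-4-hydroxyphenyl in place of 4-methoxyphenyl on a carbon with a double bond to nitrogen leaves the number within the scatter (a 1.2-fold higher number from compound 3 to compound 4 (0.07 log units; within the scatter)), which shows that this position accepts a ring with two groups and that such a ring can read the same as one carrying a single methoxy. Against the other two compounds the same ring does separate, with a modest loss relative to 4-fluorophenyl (a 3.6-fold higher number from compound 2 to compound 4 (0.55 log units; beyond the scatter)) and a modest gain relative to unsubstituted phenyl (a 3.4-fold lower number from compound 1 to compound 4 (0.53 log units; beyond the scatter)), so compound 2 keeps the lowest number of the four and a bromo on the ring does not by itself match the result of the fluoro. No measurement at hand explains any of these steps.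

Bromo and hydroxy enter together in compound 4, so what each contributes alone stays open, and a 4-hydroxyphenyl or a 2-bromophenyl group would separate the two. Also open, from the compounds shown here alone, is how this position reads with an amine or a carboxylic acid on the ring.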